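This account rests on a few compounds, and the source may have more. Where it says the series, first, only, none or still open, it means among the compounds named here.

Among the compounds with values here, compound 2 `O=C(CCCC1CCN(C(=O)CCC2CCCCC2)CC1)c1ncco1` gives 3 nM in an assay on isolated protein for inhibition of Fatty-acid amide hydrolase 1 (Homo sapiens) (a lower number here means a stronger inhibitor, a higher number a weaker inhibitor), which is the lowest of the two numbers measured so far. Its nearest neighbour is compound 1 `O=C(CCCC1CCN(C(=O)CC2CCCCC2)CC1)c1ncco1`, which in this assay gives 100 nM. Within the data shown here, the only measured step joins these two: a 33-fold lower number from compound 1 to compound 2 (1.52 log units; beyond the scatter). The unmeasured compound 3 `CC(C)(C)CC(=O)N1CCC(CCCC(=O)c2ncco2)CC1` differs from compound 2 in one place: tert-butyl in place of cyclohexylmethyl on a saturated chain carbon bound to a carbonyl carbon. Among the measured compounds shown here, the single measured step bears on this change, since the same position is altered: lengthening cyclohexyl to cyclohexylmethyl gave a large gain, whereas the move to compound 3 leaves cyclohexylmethyl for a group that carries no ring at all, which is the opposite direction of change at this position. A weakening beyond the scatter is therefore expected, roughly back toward the level of compound 1. For compound 3 the expected step is a 50-fold higher number from compound 2 to compound 3 (1.70 log units; beyond the scatter), giving an estimate of 150 nM with a range from 30 nM to 700 nM in this assay.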

Compound 3, half-maximal inhibitory concentration: 90 nM
Compound 3: middle estimate off by 1.7-fold (0.22 log units), on the high side; the range from low to high includes it.
By their numbers in this assay, from the lowest: compound 2; then compounds 3 and 1 (each within the scatter of the next).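

In this assay, the change from cyclohexylmethyl to tert-butyl gives a 30-fold higher number from compound 2 to compound 3 (1.48 log units; beyond the scatter) and so takes away the low number of compound 2; the earlier step showed only that this position can respond strongly, whereas this one shows that the gain does not survive this swap. The ringless tert-butyl and the shorter cyclohexyl cannot be told apart, with a 1.1-fold lower number from compound 1 to compound 3 (0.05 log units; within the scatter) as the step between them, so two quite different groups land at the same level and, of the three groups shown, only cyclohexylmethyl gives a low number. Nothing available explains why this position responds so sharply.

From the compounds shown here alone, whether a longer chain ending in the same cyclohexyl ring would give a still lower number stays open. So does the outcome of a phenyl ring in place of the cyclohexyl ring.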